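The source may hold more compounds than are shown below. What is called first, only, known or untested is meant among the compounds shown, and "the series" means these compounds.

Working notes on the series. In a functional assay on KB cells (Homo sapiens) for antiproliferative activity, read by sulforhodamine B assay, with a stated time of 3 days (a higher number here means that more compound is needed for the effect, a lower number that less compound is needed), compound 1 (`CCC1=C(O)c2c(oc(-c3cccc(OC)c3)cc2=O)C(CC)(CC)C1=O`), the 3-methoxyphenyl member, gives 13.3 uM, compound 2 (`CCC1=C(O)c2c(oc(-c3ccc(C)cc3C)cc2=O)C(CC)(CC)C1=O`) gives 41.2 uM and compound 3 (`CCC1=C(O)c2c(oc(-c3ccc(C)c(F)c3)cc2=O)C(CC)(CC)C1=O`) gives 28.1 uM. The measured steps are a 3.1-fold higher number from compound 1 to compound 2 (0.49 log units; beyond the scatter), a 2.1-fold higher number from compound 1 to compound 3 (0.32 log units; beyond the scatter) and a 1.5-fold lower number from compound 2 to compound 3 (0.17 log units; within the scatter). Compound 3 therefore sits level with compound 2 and apart from compound 1.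

Compound 4 (`CCC1=C(O)c2c(oc(-c3ccc(O)c(O)c3)cc2=O)C(CC)(CC)C1=O`) carries 3,4-dihydroxyphenyl in place of 3-fluoro-4-methylphenyl on an aromatic carbon next to the ring oxygen: 3,4-dihydroxyphenyl in place of 3-fluoro-4-methylphenyl on an aromatic carbon. All three measured steps swap the group at this same carbon, and none exceeds a modest size, so a modest step at most is the working expectation. Going by the values given here, no measured compound carries a hydroxy group, so the direction is weakly founded. Among the compounds with values here, the only lean comes from compound 1, the one member with oxygen on this group, at 13.3 uM. The expected step is a 1.6-fold lower number from compound 3 to compound 4 (0.19 log units; within the scatter). For compound 4 the estimated value in this assay is 18 uM, with an expected range of 6 uM to 50 uM.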

Compound 4, concentration for half-maximal effect: 10 uM
For compound 4 the middle estimate is 1.8-fold (0.26 log units) above the measured one; low and high end bracket the measured number.
By their numbers in this assay, from the lowest: compounds 4 and 1 (each within the scatter of the next); then compounds 3 and 2 (each within the scatter of the next).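

In this assay, going by these compounds alone, the 3,4-dihydroxyphenyl group gives a 2.8-fold lower number from compound 3 to compound 4 (0.45 log units; beyond the scatter) and also a 4.1-fold lower number from compound 2 to compound 4 (0.61 log units; beyond the scatter) and so is the first hydroxy-bearing group seen at this carbon, with a clear step away from both methyl-bearing groups. Against the 3-methoxyphenyl member it gives a 1.3-fold lower number from compound 1 to compound 4 (0.12 log units; within the scatter) and so stands level with it, which places the two oxygen-bearing groups together and apart from the two methyl-bearing ones across these four compounds, with no compound going against this. Nothing here measures why these groups differ.

On these data alone, whether a single hydroxy group, an amine or a carboxylic acid on this phenyl ring would sit with compound 4 stays open. As far as these compounds go, all four compounds vary only at this carbon, so the effect of a change elsewhere on the shared core also stays open.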